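A few compounds are considered here, and "the series" means these few. Any claim that something is new, unique, unknown or untested is made for them only; others in the source may bear on it.

Three boronic-acid-containing amides share one core and differ only in the aryl group on the amide nitrogen. Compound 1 `COc1ccccc1NC(=O)CCc1cccc2c1B(O)OC2` carries a methoxyphenyl group, compound 2 `Cc1ccc(NC(=O)CCc2cccc3c2B(O)OC3)cc1Br` a methyl- and bromo-substituted phenyl, and compound 3 `O=C(CCc1cccc2c1B(O)OC2)Nc1cccc(-c2ccccc2)c1` a biphenyl. In a functional assay on SK-OV-3 cells (Homo sapiens) for antiproliferative activity, read by MTT assay, with a stated time of 72 h (a lower number here means a stronger inhibitor, a higher number a weaker inhibitor), compound 1 gives 200 nM, compound 2 gives 600 nM, and compound 3 gives 250 nM. Compound 3 thus stands second highest of the three numbers: its value and that of compound 1 lie within the scatter of each other, so no order between them can be claimed, while compound 2 shows a higher number, beyond the scatter.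

Compound 4 `CSc1ccc(-c2cccc(NC(=O)CCc3cccc4c3B(O)OC4)c2)cc1` is the next step from compound 3. The change is methylsulfanyl in place of hydrogen on an aromatic carbon, so the phenyl becomes a 4-(methylsulfanyl)phenyl, para to a large group. Among the measured compounds shown here, no step between measured compounds in this assay isolates a change of this kind, and the three measured values span only a modest range. The account therefore expects for compound 4 a step of a 1.1-fold lower number from compound 3 to compound 4 (0.06 log units; within the scatter) that is small, in either direction, and most likely not beyond the scatter. The estimate for compound 4 in this assay is 220 nM, within a range from 80 nM to 600 nM.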

Compound 4, half-maximal inhibitory concentration: 140 nM
Estimate against measurement, compound 4: 1.6-fold (0.20 log units) above, within the range that was stated.
By their numbers in this assay, from the lowest: compounds 4, 1 and 3 (each within the scatter of the next); then compound 2.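

With the phenyl of compound 3 becoming the 4-(methylsulfanyl)phenyl of compound 4, the series gains its first comparison between measured compounds that differ in one place: in this assay, the change gives a 1.8-fold lower number from compound 3 to compound 4 (0.25 log units; within the scatter) for methylsulfanyl in place of hydrogen. At this position, para to a large group, the added methylsulfanyl, with its one carbon and one sulfur, therefore leaves a difference that cannot be told from the scatter, and no order between the two compounds can be claimed. The data shown offer no explanation for the size of this step.

From the compounds shown here alone, whether the same position would give a similarly small step with a methoxy group, a methyl group, an amine, a carboxylic acid or a longer chain such as ethylsulfanyl remains open, as does whether the sulfur atom plays any part in the result. Also open, going by these compounds, is whether methylsulfanyl would give a step of similar size on the differently substituted aryl groups of compound 1 and compound 2, where its effect cannot be inferred from this single pair.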